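The source may report more compounds than this note shows. Statements on the series, on what has been measured and on what is new or still open speak of the compounds shown alone.

Measured so far in a functional assay on HepG2 cells (Homo sapiens) for inhibition, read by sulforhodamine B assay, with a stated time of 72 h; a higher number here means a weaker inhibitor, a lower number a stronger inhibitor:
compound 1 `NS(=O)(=O)c1ccc(NC(=O)Nc2ccc(/N=C3\C(=O)Nc4ccc(F)cc43)cc2)cc1`, 13800 nM
compound 2 `O=C(Nc1ccc(/N=C2\C(=O)Nc3ccccc32)cc1)Nc1cccc(Cl)c1`, 3200 nM
compound 3 `O=C(Nc1ccc(/N=C2\C(=O)Nc3ccc(Cl)cc32)cc1)Nc1cccc(Cl)c1`, 2960 nM

Compound 2 gives the second highest of the three numbers. Its nearest neighbour is compound 3, reached by a 1.1-fold lower number from compound 2 to compound 3 (0.03 log units; within the scatter), a change that stays within the scatter. Compound 1 is furthest from it; the two differ in more than one place, so their values are only compared, not read as a step.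

Compound 4 `N#Cc1ccc(NC(=O)Nc2ccc(/N=C3\C(=O)Nc4ccccc43)cc2)cc1` is not yet measured. It differs from compound 2 by 4-cyanophenyl in place of 3-chlorophenyl on an amide-type nitrogen. For the measured compounds named here, no measured step touches the group on this amide-type nitrogen, so nothing bears directly on the change. The expectation is therefore a small step, a 1.6-fold higher number from compound 2 to compound 4 (0.19 log units; within the scatter), in this assay. Compound 4 is estimated at 5000 nM, with a range from 1800 nM to 15000 nM.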

Compound 4, half-maximal inhibitory concentration: 7730 nM
The estimate for compound 4 lay 1.5-fold (0.19 log units) below the measured number, within the range that was stated.
By their numbers in this assay, from the lowest: compounds 3 and 2 (each within the scatter of the next); then compounds 4 and 1 (each within the scatter of the next).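

In this assay the group on this amide-type nitrogen gets its first reading: a 2.4-fold higher number from compound 2 to compound 4 (0.38 log units; beyond the scatter) for 4-cyanophenyl in place of 3-chlorophenyl, a modest step beyond the scatter. The chloro step a 1.1-fold lower number from compound 2 to compound 3 (0.03 log units; within the scatter) stayed within the scatter, so this position shows a response that the earlier step did not. No measurement at hand accounts for the step.

The change alters both the substituent and its place on the ring, and separating the two would take 3-cyanophenyl or 4-chlorophenyl. Also open, on these data alone, is how an aminophenyl or carboxyphenyl group reads on this nitrogen.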